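This account rests on a few compounds, and the source may have more. Where it says the series, first, only, none or still open, it means among the compounds named here.

Among the compounds with values here, compound 2, `N=S1(=O)CC(Nc2nonc2/C(=N/O)Nc2ccc(F)c(Br)c2)C1`, gives 208 nM in an assay on isolated protein for inhibition of Indoleamine 2,3-dioxygenase 1 (Homo sapiens), read by fluorescence, with a stated time of 60 min (a higher number here means a weaker inhibitor, a lower number a stronger inhibitor), the higher of the two numbers so far; compound 1, `O=S1(=O)CC(Nc2nonc2/C(=N/O)Nc2ccc(F)c(Br)c2)C1`, gives 99 nM in this assay, and the step of a 2.1-fold higher number from compound 1 to compound 2 (0.32 log units; beyond the scatter) was modest but beyond the scatter. Compound 3, `NNS(=O)(=O)CCNc1nonc1/C(=N/O)Nc1ccc(F)c(Br)c1`, differs from compound 2 by a group of 7 heavy atoms (2 carbon, 2 nitrogen, 2 oxygen, 1 sulfur; no ring) in place of a group of 6 heavy atoms (3 carbon, 1 nitrogen, 1 oxygen, 1 sulfur; one four-membered non-aromatic ring with 1 hetero atom), on a nitrogen on an aromatic ring. Within the data shown here, the only measured step touches the same position but exchanges one atom inside the four-membered ring, so it bears weakly on an opening of that ring into a 2-(aminosulfamoyl)ethyl chain. For compound 3 a step of about a 1.2-fold higher number from compound 2 to compound 3 (0.08 log units; within the scatter) is expected, with the number likely staying within the scatter of compound 2. The estimate for compound 3 is 250 nM, ranging from 80 nM to 800 nM.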

Compound 3, half-maximal inhibitory concentration: 135 nM
Beside the measured number, compound 3's estimate is 1.9-fold (0.27 log units) above it; low and high end bracket the measured number.
By their numbers in this assay, from the lowest: compounds 1, 3 and 2 (each within the scatter of the next, the first and the last beyond it).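

Opening the four-membered ring into the 2-(aminosulfamoyl)ethyl chain leaves the reading in this assay close to both ring compounds, with a 1.5-fold lower number from compound 2 to compound 3 (0.19 log units; within the scatter) and a 1.4-fold higher number from compound 1 to compound 3 (0.13 log units; within the scatter). At this position, on a nitrogen on an aromatic ring, the ring is therefore not required for a number in this range among these compounds. Nothing available accounts for why the open chain and the rings read alike. As far as these compounds go, how an ethyl chain ending in an amine or a carboxylic acid, or a longer chain, would read here stays open.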